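A branched chain replaces an ether chain

The source may hold more compounds than are shown below. What is called first, only, known or untested is meant among the compounds shown, and "the series" means these compounds.

compound 1 `O=C(CCCCOc1no[n+]([O-])c1S(=O)(=O)c1ccccc1)NO` gives 1910 nM
compound 2 `O=C(COCCOc1no[n+]([O-])c1S(=O)(=O)c1ccccc1)NO` gives 7400 nM

In a functional assay on KG-1 cells (Homo sapiens) for inhibition, read by MTT assay, with a stated time of 48 h (on this read-out higher numbers stand for weaker inhibition and lower numbers for stronger inhibition), compound 2 has the higher of the two numbers (7400 nM). Compound 3 `CC(C)(COc1no[n+]([O-])c1S(=O)(=O)c1ccccc1)C(=O)NO` has not yet been measured. It differs from compound 2 in one place (1-(hydroxycarbamoyl)-1-methylethyl in place of ((hydroxycarbamoyl)methoxy)methyl on a saturated chain carbon bound to an oxygen on an aromatic ring): 1-(hydroxycarbamoyl)-1-methylethyl stands in place of ((hydroxycarbamoyl)methoxy)methyl. Within the data shown here, only one measured step bears on this, and it concerns the same chain but not the same change (a 3.9-fold higher number from compound 1 to compound 2 (0.59 log units; beyond the scatter)). It was modest. With so little evidence, no step beyond the scatter is expected, and the expected step is small (a 1.2-fold higher number from compound 2 to compound 3 (0.09 log units; within the scatter)). Compound 3 is estimated at 9000 nM (expected range 3000 nM to 27000 nM).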

Compound 3, half-maximal inhibitory concentration: 6080 nM
For compound 3 the middle estimate is 1.5-fold (0.17 log units) above the measured one; measured number inside the range.
By their numbers in this assay, from the lowest: compound 1; then compounds 3 and 2 (each within the scatter of the next).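

In this assay, 1-(hydroxycarbamoyl)-1-methylethyl in place of ((hydroxycarbamoyl)methoxy)methyl gives a 1.2-fold lower number from compound 2 to compound 3 (0.09 log units; within the scatter), so on a saturated chain carbon bound to an oxygen on an aromatic ring these two chains cannot be told apart. The same branched chain in place of 3-(hydroxycarbamoyl)propyl gives a 3.2-fold higher number from compound 1 to compound 3 (0.50 log units; beyond the scatter), so among the three chains only 3-(hydroxycarbamoyl)propyl stands apart. Nothing available explains either step. The compounds shown leave open how a longer chain, or a carboxylic acid in place of the hydroxycarbamoyl group, would read in this assay.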